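Cytotoxicity of a triazole-linked series on monocytic cells

The compounds below may be only part of what the source reports. "The series", "measured", "known", "first", "only" and "open" are said of these compounds alone.

Measured so far in a functional assay on THP-1 cells (Homo sapiens) for cytotoxicity, read by MTT assay, with a stated time of 24 h; on this read-out higher numbers stand for weaker inhibition and lower numbers for stronger inhibition:
Compound 1 `COc1ccc(NC(=O)Cn2cc(Cn3nc(N)c4c(C(F)(F)F)cc(-c5ccccc5)nc43)nn2)cc1` gives 56.7 ug/mL.
Compound 2 `Nc1nn(Cc2cn(CC(=O)Nc3ccc(F)cc3)nn2)c2nc(-c3ccccc3)cc(C(F)(F)F)c12` gives 49.6 ug/mL.
Compound 3 `Nc1nn(Cc2cn(CC(=O)Nc3ccccc3Br)nn2)c2nc(-c3ccccc3)cc(C(F)(F)F)c12` gives 95.3 ug/mL.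

Compound 1 sits second highest of the three numbers in this assay; all three lie within the scatter of one another, so no order among them can be read. Compound 4 `Nc1nn(Cc2cn(CC(=O)Nc3ccc(F)cc3Br)nn2)c2nc(-c3ccccc3)cc(C(F)(F)F)c12` differs from compound 1 in one place: 2-bromo-4-fluorophenyl in place of 4-methoxyphenyl on an amide-type nitrogen. Among the compounds with values here, two measured steps bear on this change. The step of a 1.7-fold higher number from compound 1 to compound 3 (0.23 log units; within the scatter) brings in the bromine alone, and the step of a 1.1-fold lower number from compound 1 to compound 2 (0.06 log units; within the scatter) brings in the fluorine alone; neither moves beyond the scatter. Compound 4 joins both substituents, so a step of similar size, if any, is expected: a 1.4-fold higher number from compound 1 to compound 4 (0.15 log units; within the scatter). Compound 4 is therefore estimated at 80 ug/mL, with a range from 40 ug/mL to 160 ug/mL.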

Compound 4, half-maximal inhibitory concentration: 65.6 ug/mL
Estimate against measurement, compound 4: 1.2-fold (0.09 log units) above; the measured number falls inside the stated range.
By their numbers in this assay, from the lowest: compounds 2, 1, 4 and 3 (each within the scatter of the next).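

In this assay, the two halogens together stay within the scatter of the 4-methoxyphenyl compound (a 1.2-fold higher number from compound 1 to compound 4 (0.06 log units; within the scatter)). Adding either halogen to the compound carrying the other changes nothing beyond the scatter: fluoro (a 1.5-fold lower number from compound 3 to compound 4 (0.16 log units; within the scatter)) and bromo (a 1.3-fold higher number from compound 2 to compound 4 (0.12 log units; within the scatter)). The group on the amide-type nitrogen thus carries both halogens at once without a step beyond the scatter, and no evidence on the cause is at hand. Going by these compounds, whether any group here moves the number beyond the scatter stays open. An amine, a carboxylic acid or a longer chain on that phenyl ring would test this.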